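Thiophene for fluorophenyl at the aryl position of the core

The compounds below may be only part of what the source reports. "The series", "measured", "known", "first", "only" and "open" are said of these compounds alone.

Compound 1 `c1ccc(-c2cn3ccnc3c(-c3ccc4ncn(C5CCCCC5)c4c3)n2)cc1` gives 45.3% in a functional assay on NCI-H23 cells (Homo sapiens) for inhibition, read by sulforhodamine B assay, with a stated time of 48 h, tested at 10 uM; on this read-out lower numbers stand for less inhibition and higher numbers for more inhibition at the one concentration tested (going by the name of the read-out). Within the data shown here, compound 2 `Fc1ccc(-c2cn3ccnc3c(-c3ccc4ncn(C5CCCCC5)c4c3)n2)cc1` gives 2.36% in this assay, the lowest of the two numbers; the single measured step is a number 42.9 percentage points lower from compound 1 to compound 2 (beyond the scatter), fluoro in place of hydrogen on an aromatic carbon. Compound 3 `c1cn2cc(-c3ccsc3)nc(-c3ccc4ncn(C5CCCCC5)c4c3)c2n1` differs from compound 2 by thiophen-3-yl in place of 4-fluorophenyl on an aromatic carbon. Among the measured compounds shown here, no measured step covers this exchange; the only guide is that compound 1, without the fluorine, gives 45.3%. A rise toward that number is expected but uncertain, a number 22.6 percentage points higher from compound 2 to compound 3 (beyond the scatter). Compound 3 is estimated at 25%, range -5% to 55%.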

Compound 3, a percentage reported as inhibition, at one concentration (the size of the read-out at that concentration, not a potency): 10%
Compound 3: middle estimate off by 15 percentage points, on the high side; low and high end bracket the measured number.
By their numbers in this assay, from the lowest: compounds 2 and 3 (each within the scatter of the next); then compound 1.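

In this assay, thiophen-3-yl and 4-fluorophenyl are not told apart at this position, with a number 7.6 percentage points higher from compound 2 to compound 3 (within the scatter) as the step between them. Replacing phenyl with thiophen-3-yl gives a number 35.3 percentage points lower from compound 1 to compound 3 (beyond the scatter), so among the three groups only the phenyl of compound 1 stands apart from the others, and a second replacement at this position now also lies far from it. No measurement on hand accounts for this.

Open, from the compounds shown here alone, is whether a pyridyl ring or a morpholine amine at this position would stay near compound 1 or near compound 2 and compound 3.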